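Hydroxymethyl in place of vinyl on the amino alcohol chain

A few compounds are considered here, and "the series" means these few. Any claim that something is new, unique, unknown or untested is made for them only; others in the source may bear on it.

Among the measured compounds shown here, in a functional assay on the whole organism (spleen, spleen) with Rattus norvegicus as the target (on this read-out higher numbers stand for an effect only at larger amounts of compound and lower numbers for an effect already at smaller amounts), compound 2 `C=CCC(N)(CO)CCc1ccc(OCCCCCCC)cc1` gives 1.9 mg/kg, the only number among the two values shown. Compound 1 `CCCCCCCCc1ccc(CCC(N)(CO)C(=O)O)cc1` reaches only the limit > 10 mg/kg in this assay, a limit rather than a number, as noted at the limit of > 10 mg/kg in this assay, at which 1 of the 2 values shown sits. Compound 3 `CCCCCCCOc1ccc(CCC(N)(CO)CCO)cc1` differs from compound 2 by hydroxymethyl in place of vinyl on a saturated chain carbon, two bonds along the chain from an amine nitrogen. For the measured compounds named here, no measured pair shows this change, so the step from compound 2 to compound 3 in this assay is expected to be small, a 1.6-fold higher number from compound 2 to compound 3 (0.20 log units; within the scatter), and not clearly beyond the scatter. Compound 3 is therefore estimated at 3 mg/kg, within 1 mg/kg to 10 mg/kg.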

Compound 3, dose for 50% inhibition: 0.038 mg/kg
Estimate against measurement, compound 3: 79-fold (1.90 log units) above; the measured number lies below the stated range.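

In this assay, the change from allyl to 2-hydroxyethyl on a saturated chain carbon, two bonds along the chain from an amine nitrogen, gives a 50-fold lower number from compound 2 to compound 3 (1.70 log units; beyond the scatter). Among the compounds shown here, this is the first readable step, and it shows that this place responds strongly to the change, with an effect already at much smaller doses. Nothing shown here accounts for the size of the step.

On these data alone, whether the hydroxyl itself or the loss of the double bond carries the step remains open. So does how 3-hydroxypropyl or 2-aminoethyl at this place would compare.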